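From Cyano to Methoxy on Compound 1

The compounds below may be only part of what the source reports. "The series", "measured", "known", "first", "only" and "open" are said of these compounds alone.

Measured so far in an ADME assay on a cell-free system (plasma, Rattus norvegicus) for protein binding
- compound 1 `CNc1nccc(N2CC[C@H](NC(=O)Nc3cccc(C#N)c3)C2)n1` gives 91.6%
- compound 2 `O=C(Nc1ccc(Cl)c(C(F)(F)F)c1)N[C@H]1CCN(c2ccnc(NC3CC3)n2)C1` gives 99.9%

Of the two, compound 1 leaves the larger share unbound. Compound 1 stands at 91.6% and compound 2 at 99.9% and that gap lies beyond the usual scatter.

Compound 3 `CNc1nccc(N2CC[C@H](NC(=O)Nc3cccc(OC)c3)C2)n1` has not yet been measured. It keeps the core of compound 1 and carries methoxy in place of cyano on an aromatic carbon, meta to a large group. The same change reads as 3-cyanophenyl to 3-methoxyphenyl methoxy in place of cyano on an aromatic carbon and nothing else differs.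

Within the data shown here, the measured compounds offer no step that differs in one place, and compound 2 differs from compound 1 in more than one. The expectation therefore rests on the structural change alone. The estimated step a 1.1-fold lower unbound fraction from compound 1 to compound 3 (0.05 log units; within the scatter) is expected to stay within the scatter of this assay and to lean, if anything, toward more binding. For compound 3 the expected value is 92.5% with an estimated range from 85% to 97% for this measurement.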

Compound 3, plasma protein binding: 93.9%
For compound 3 the middle estimate is 1.2-fold (0.09 log units) (unbound fraction) above the measured one; the measured number falls inside the stated range.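

In this assay, putting methoxy in place of cyano on an aromatic carbon, meta to a large group, gives the first step read between measured compounds that differ in one place: a 1.4-fold lower unbound fraction from compound 1 to compound 3 (0.14 log units; within the scatter). At this position, 3-cyanophenyl and 3-methoxyphenyl therefore cannot be told apart by plasma protein binding, so this exchange of one group for another of the same heavy-atom count leaves the unbound share within what repeated measurements would give. Nothing at hand bears on why these two groups read alike here.

The compounds shown cover only these two groups at this place, so it stays open whether a group of another kind, such as an amine or a carboxylic acid, or a longer chain such as ethoxy, would also stay within the scatter. From the compounds shown here alone, it also stays open whether the exchange of cyano for methoxy would read the same on a different core, or with the group at another place on the same aromatic ring.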